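Swapping an Alkene Chain for a Methoxybenzyl Group

This account rests on a few compounds, and the source may have more. Where it says the series, first, only, none or still open, it means among the compounds named here.

Measured compounds:
- compound 1, `CC(C)CCn1cnc2c(NCc3cccc(Cl)c3)nc(N[C@H]3CC[C@H](N)CC3)nc21`: 6600 nM
- compound 2, `CCCCCCn1cnc2c(Nc3cccc(Cl)c3)nc(N[C@H]3CC[C@H](N)CC3)nc21`: 5100 nM
- compound 3, `CC(C)=CCn1cnc2c(Nc3cccc(Cl)c3)nc(N[C@H]3CC[C@H](N)CC3)nc21`: 7000 nM

In a functional assay on BT-474 cells (Homo sapiens) for inhibition, read by fluorescence, with a stated time of 72 h (a higher number here means a weaker inhibitor of growth, a lower number a stronger inhibitor of growth), compound 3 gives 7000 nM. Its number lies together with those of compound 1 and compound 2: the three values sit within the usual scatter of one another, so no one of them can be set apart from the others.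

Compound 4, `COc1ccc(Cn2cnc3c(Nc4cccc(Cl)c4)nc(N[C@H]4CC[C@H](N)CC4)nc32)cc1`, has not yet been measured. It differs from compound 3 in one place: 4-methoxyphenyl in place of 2-methylprop-1-en-1-yl on a saturated chain carbon bound to an aromatic nitrogen.

Within the data shown here, only one measured step exists, a 1.4-fold higher number from compound 2 to compound 3 (0.14 log units; within the scatter), and it concerns a different exchange, one chain for another at the same position. It shows that changing the group at that position by a small amount left the number within the scatter. Nothing measured speaks to a ring group entering there, so no firm direction can be drawn. The expectation for compound 4 is therefore a step of a 1.4-fold lower number from compound 3 to compound 4 (0.15 log units; within the scatter), meaning no change beyond the scatter. The estimated value for compound 4 in this assay is 5000 nM, with a range from 1500 nM to 16000 nM.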

Compound 4, concentration for 50% growth inhibition: 8200 nM
The estimate for compound 4 lay 1.6-fold (0.21 log units) below the measured number; measured number inside the range.
By their numbers in this assay, from the lowest: compounds 2, 1, 3 and 4 (each within the scatter of the next).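

In this assay, a ring at this position does not set the number apart from those of the open chains: 4-methoxyphenyl in place of 2-methylprop-1-en-1-yl gives a 1.2-fold higher number from compound 3 to compound 4 (0.07 log units; within the scatter), and 4-methoxyphenyl in place of pentyl gives a 1.6-fold higher number from compound 2 to compound 4 (0.21 log units; within the scatter). Among these compounds, the earlier compounds compared only chains with each other, so this is the first sign that an aromatic ring carrying a methoxy group can stand on this saturated chain carbon bound to an aromatic nitrogen with the number staying within the scatter. No measurement at hand gives a reason for this.

As far as these compounds go, it remains open whether an amine or a carboxylic acid at this position would also stay within the scatter. From the compounds shown here alone, a benzyl group without the methoxy is equally open.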